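The source may hold more compounds than are shown below. What is called first, only, known or untested is meant among the compounds shown, and "the series" means these compounds.

Working notes on the series. Compound 1 `C=CCOC(=O)SCCCCCCNC(=O)c1cc(-c2ccncc2)n[nH]1` and compound 2 `O=C(OCc1ccccc1)SCCCCCCNC(=O)c1cc(-c2ccncc2)n[nH]1` share a core that carries a six-carbon chain ending in a thiocarbonyl ester. In a functional assay on HT-29 cells (Homo sapiens) for inhibition, read by MTT assay, with a stated time of 96 h (a lower number here means a stronger inhibitor of growth, a higher number a weaker inhibitor of growth), compound 1 gives 11900 nM, and compound 2 gives 22000 nM. Within the data shown here, the one measured step, a 1.8-fold higher number from compound 1 to compound 2 (0.27 log units; within the scatter), stays inside the scatter, so the two numbers cannot be ordered; compound 2 carries the highest of the two numbers, with compound 1 its only neighbour.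

Compound 3 `CC(=O)SCCCCCCNC(=O)c1cc(-c2ccncc2)n[nH]1` is not yet measured. The change from compound 2 is methyl in place of benzyloxy on a carbonyl carbon; cut one bond further out it reads benzyloxycarbonyl to acetyl. Among the measured compounds shown here, no measured step covers this change: the step from compound 1 to compound 2 only swaps phenyl for vinyl on the chain carbon bound to the oxygen, and it was within scatter. Since that step showed no movement beyond scatter, a step of about a 1.5-fold lower number from compound 2 to compound 3 (0.17 log units; within the scatter) in this assay is expected, with no clear direction. Compound 3 is therefore estimated at 15000 nM, with a range from 5000 nM to 45000 nM.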

Compound 3, concentration for 50% growth inhibition: 23100 nM
Estimate against measurement, compound 3: 1.5-fold (0.19 log units) below; the measured number falls inside the stated range.
By their numbers in this assay, from the lowest: compounds 1, 2 and 3 (each within the scatter of the next).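

In this assay the change of methyl in place of benzyloxy on a carbonyl carbon gives a 1.1-fold higher number from compound 2 to compound 3 (0.02 log units; within the scatter) and the change of methyl in place of allyloxy gives a 1.9-fold higher number from compound 1 to compound 3 (0.29 log units; within the scatter) in this series, and the three numbers cannot be ordered. The earlier step exchanged only phenyl for vinyl and kept the oxygen on the carbonyl carbon, whereas here that oxygen leaves as well: benzyloxy, with 8 heavy atoms and an aromatic ring, gives way to methyl, with 1 heavy atom and no ring, and the number still stays within the scatter. Nothing at hand bears on the reason for this result.

Left open is whether any group on this carbonyl carbon gives a step beyond the scatter, for instance an amine or a longer alkyl chain in place of methyl. Also open, from the compounds shown here alone, is what the sulfur-linked end contributes at all, as all three compounds carry the same six-carbon chain and a carbonyl on the sulfur, so a free thiol or a shorter chain would be the informative comparison.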